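Swapping an Amide for a Urea on a Sulfonate Ester

This account rests on a few compounds, and the source may have more. Where it says the series, first, only, none or still open, it means among the compounds named here.

Three sulfonate esters have been measured in a functional assay on HT-29 cells (Homo sapiens) for antiproliferative activity, read by sulforhodamine B assay, with a stated time of 48 h; on this read-out lower numbers stand for stronger inhibition and higher numbers for weaker inhibition. Compound 1 `CCC(=O)Nc1cccc(S(=O)(=O)Oc2ccccc2C(C)C)c1` gives 22000 nM, compound 2 `CC(C)C(=O)Nc1ccc(S(=O)(=O)Oc2ccccc2C(C)C)cc1` gives 14000 nM, and compound 3 `CC(C)C(=O)Nc1ccc(S(=O)(=O)Oc2ccccc2I)cc1` gives 13000 nM. Compound 3 thus carries the lowest number of the three, but its separation from compound 2 is a 1.1-fold lower number from compound 2 to compound 3 (0.03 log units; within the scatter), and its separation from compound 1 is also within the scatter, so no ranking among them can be claimed.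

The next compound, compound 4 `O=C(NCCCCl)Nc1ccc(S(=O)(=O)Oc2ccccc2I)cc1`, keeps the iodophenyl sulfonate of compound 3 and changes only the acyl group: (3-chloropropyl)amino in place of isopropyl on a carbonyl carbon. Within the data shown here, the single measured step, the one from compound 2 to compound 3, concerns the aromatic substituent and not the carbonyl side, so no measured step bears on this change. With nothing pointing either way, the expectation in this assay is a step of a 1.1-fold lower number from compound 3 to compound 4 (0.03 log units; within the scatter), that is, no move beyond the scatter. Compound 4 is therefore estimated at 12000 nM, with a range from 4000 nM to 36000 nM.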

Compound 4, half-maximal inhibitory concentration: 9600 nM
Compound 4: middle estimate off by 1.3-fold (0.10 log units), on the high side, and the stated range covers the measured number.
By their numbers in this assay, from the lowest: compounds 4, 3, 2 and 1 (each within the scatter of the next, the first and the last beyond it).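

Replacing isopropyl with (3-chloropropyl)amino on a carbonyl carbon turns the amide of compound 3 into the urea of compound 4, and in this assay this gives a 1.4-fold lower number from compound 3 to compound 4 (0.13 log units; within the scatter). Among these compounds, this is the first measured step on the carbonyl side of these sulfonate esters, as the earlier step concerned only the aromatic substituent, and it shows that a group of 5 heavy atoms in place of 3, carrying a chlorine and 1 hydrogen-bond donor, leaves the number within the scatter. Nothing at hand gives a reason for this outcome.

The compounds shown leave open whether the urea nitrogen and the chlorine each matter on their own, which a urea carrying a plain propyl chain would separate. They also leave open whether a 2-chloroethyl group, a longer chloroalkyl chain or a terminal amine at this place would move the number beyond the scatter.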